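This account rests on a few compounds, and the source may have more. Where it says the series, first, only, none or still open, it means among the compounds named here.

For the measured compounds named here, in a physicochemical assay for solubility, at pH 6.6 (on this read-out higher numbers stand for higher solubility and lower numbers for lower solubility), compound 1 `CC(c1ccccc1)c1nc2c(C(F)(F)F)cccc2c(C(=O)O)c1O` gives 1550 ug/mL, while compound 2 `CC(Cc1nc2c(C(F)(F)F)cccc2c(C(=O)O)c1O)c1ccccc1` gives 680 ug/mL, the lower of the two numbers measured so far. Compound 3 `O=C(O)c1c(O)c(C2Cc3ccccc3C2)nc2c(C(F)(F)F)cccc12` has not yet been measured. It carries 2,3-dihydro-1H-inden-2-yl in place of 2-phenylpropyl on an aromatic carbon, next to the ring nitrogen and ortho to a hydroxy group: 2,3-dihydro-1H-inden-2-yl in place of 2-phenylpropyl on an aromatic carbon. Going by the values given here, only one measured step bears on this change: a 2.3-fold lower number from compound 1 to compound 2 (0.36 log units; beyond the scatter), a modest difference beyond the scatter, seen when 2-phenylpropyl took the place of 1-phenylethyl. That step involves a different exchange of groups, so it offers only a rough guide to size and none to direction. In this assay, a step no larger than that one is expected, and most likely none beyond the scatter. Compound 3 is expected at 750 ug/mL, with an estimated range of 300 ug/mL to 1800 ug/mL. This estimate amounts to a 1.1-fold higher number from compound 2 to compound 3 (0.04 log units; within the scatter).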

Compound 3, solubility: 700 ug/mL
Beside the measured number, compound 3's estimate is 1.1-fold (0.03 log units) above it; the measured number falls inside the stated range.
By their numbers in this assay, from the lowest: compounds 2 and 3 (each within the scatter of the next); then compound 1.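

In this assay, 2,3-dihydro-1H-inden-2-yl in place of 2-phenylpropyl on the aromatic carbon next to the ring nitrogen gives a 1.0-fold higher number from compound 2 to compound 3 (0.01 log units; within the scatter) and so separates compound 2 and compound 3 by no more than the scatter, which shows that tying the side chain into a five-membered non-aromatic ring leaves the read-out unmoved here. The other new step, a 2.2-fold lower number from compound 1 to compound 3 (0.35 log units; beyond the scatter), is beyond the scatter and comes alongside a 2.3-fold lower number from compound 1 to compound 2 (0.36 log units; beyond the scatter), so among these three compounds, 1-phenylethyl now stands apart from two different groups rather than one. Nothing measured accounts for these numbers.

From the compounds shown here alone, how this assay would read with a benzyl group at this position remains open. So does the effect of a side group carrying an amine or an ether oxygen, since every group shown here is built of carbon alone.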